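This account rests on a few compounds, and the source may have more. Where it says the series, first, only, none or still open, it means among the compounds named here.

In an assay on MCF7 cells for inhibition of Serine-protein kinase ATM (Homo sapiens), read by immunofluorescence, with a stated time of 1 h (a higher number here means a weaker inhibitor, a lower number a stronger inhibitor), compound 1, `COCCOc1cc2ncnc(-n3nc(-c4ccccn4)nc3N)c2cc1OCCOC`, gives 2300 nM. Compound 2, `COc1cc2nc(Cl)nc(-n3nc(-c4ccccn4)nc3N)c2cc1OC`, reaches only the limit of the assay, > 40000 nM, which is not a measured number. Compound 3, `CCOC(=O)CNc1nc(-n2nc(-c3ccccn3)nc2N)c2cc(OC)c(OC)cc2n1`, likewise stands at a limit, > 40000 nM, so no number is known for it. For the measured compounds named here, the single step that touches the place now in question, a step that the two limits leave unreadable from compound 2 to compound 3, puts ((ethoxycarbonyl)methyl)amino in place of chloro on an aromatic carbon, and its size cannot be read because the limit of > 40000 nM in this assay, at which 2 of the 3 values shown sit, hides both ends of it. Compound 4, `CCN(CC)c1nc(-n2nc(-c3ccccn3)nc2N)c2cc(OC)c(OC)cc2n1`, differs from compound 3 by diethylamino in place of ((ethoxycarbonyl)methyl)amino on an aromatic carbon. Going by the values given here, no measured step shows what such a change does at this position, and the one step that does touch it is unreadable, so only a weak expectation can be formed. The step from compound 3 to compound 4 is estimated as an at least 1.3-fold lower number from compound 3 to compound 4 (0.12 log units; that floor lies within the scatter). Compound 4 is therefore expected to give about 30000 nM, within the range 6000 nM to 100000 nM, with a fair chance that the assay again reports only a limit.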

Compound 4, half-maximal inhibitory concentration: > 40000 nM
Compound 4: only a limit was reported (the forecaster's own chance of this, stated with the estimate: 55%); middle value at least 1.3-fold (0.12 log units) away from the limit.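

Compound 4 adds no readable step: its steps from compound 2 and compound 3 cannot be read, as all three values are limits, not numbers: the limit of > 40000 nM in this assay, at which 3 of the 4 values shown sit. The compounds shown leave open how diethylamino, ((ethoxycarbonyl)methyl)amino and chloro at this place compare with one another.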